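Aryl exchange on a compound at the assay limit

A few compounds are considered here, and "the series" means these few. Any claim that something is new, unique, unknown or untested is made for them only; others in the source may bear on it.

In a functional assay on PC-3 cells (Homo sapiens) for antiproliferative activity, read by MTT assay, with a stated time of 48 h (on this read-out higher numbers stand for weaker inhibition and lower numbers for stronger inhibition), compound 1 `O=C(/C=C\Nc1ccc(Cl)cc1)c1cn(-c2ccccc2)nc1-c1ccc(F)cc1` gives 3800 nM as its measured value. Compound 2 `O=C(/C=C\Nc1ccc(C(F)(F)F)cc1)c1cn(-c2ccccc2)nc1-c1ccc(F)cc1` gives > 50000 nM as a limit and not a number. Compound 2 therefore sits at the limit of > 50000 nM in this assay, at which 1 of the 2 values shown sits, and has no exact place on the scale.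

Within the data shown here, the single measured step is an at least 13-fold higher number from compound 1 to compound 2 (1.11 log units; beyond the scatter) and it is large, but it lies at the chloro place and not at the place changed next. Compound 3 `COc1cc(-c2nn(-c3ccccc3)cc2C(=O)/C=C\Nc2ccc(C(F)(F)F)cc2)cc(OC)c1OC` differs from compound 2 by 3,4,5-trimethoxyphenyl in place of 4-fluorophenyl on an aromatic carbon with the trifluoromethyl kept. Among the measured compounds shown here, no measured step covers this exchange, so any forecast of its size rests on thin ground.

With the trifluoromethyl retained, compound 3 is expected to stay nearer to compound 2 than to compound 1 in this assay given the size of an at least 13-fold higher number from compound 1 to compound 2 (1.11 log units; beyond the scatter) and only a modest move toward stronger inhibition is expected. The estimated change is an at least 2.0-fold lower number from compound 2 to compound 3 (0.30 log units; that floor lies within the scatter) toward lower numbers. The estimate for compound 3 is 25000 nM with an expected range from 5000 nM to 50000 nM for this measurement.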

Compound 3, half-maximal inhibitory concentration: > 50000 nM
Compound 3 was reported as a limit (the forecaster's own chance of this, stated with the estimate: 45%); middle value at least 2.0-fold (0.30 log units) from the limit.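

In this assay compound 3 gives > 50000 nM, a limit and not a number. Compound 2 is also a limit, so no step can be read for 3,4,5-trimethoxyphenyl in place of 4-fluorophenyl: the limit of > 50000 nM in this assay, at which 2 of the 3 values shown sit. The compounds shown leave open how large this exchange is, and what it does when the chloro of compound 1 is kept.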